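Dimethylamino to hydrogen on the alkynyl phenyl ring

This account rests on a few compounds, and the source may have more. Where it says the series, first, only, none or still open, it means among the compounds named here.

Measured so far:
Compound 1 `COC(=O)c1sc2cc(C#Cc3ccccc3F)cnc2c1N` — in a functional assay on A375-C5 cells (Homo sapiens) for inhibition, read by sulforhodamine B assay, with a stated time of 48 h (a higher number here means a weaker inhibitor of growth, a lower number a stronger inhibitor of growth), compound 1 sits at the limit > 150000 nM, a limit and not a number.
Compound 2 `COC(=O)c1sc2cc(C#Cc3ccc(N(C)C)cc3)cnc2c1N` — in this assay compound 2 gives 17700 nM.

For the measured compounds named here, compound 2 holds the only number in the set; the other value is a limit (the limit of > 150000 nM in this assay, at which 1 of the 2 values shown sits). Compound 3 `COC(=O)c1sc2cc(C#Cc3ccccc3)cnc2c1N` differs from compound 2 by hydrogen in place of dimethylamino on an aromatic carbon. Going by the values given here, no step between measured compounds exists, so the expected size rests on the two values alone; a loss beyond the scatter is expected, the step of a 3.4-fold higher number from compound 2 to compound 3 (0.53 log units; beyond the scatter) being the estimate. Compound 3 is expected at 60000 nM, between 20000 nM and 200000 nM.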

Compound 3, concentration for 50% growth inhibition: > 150000 nM
Compound 3: a limit, no number (the forecaster's own chance of this, stated with the estimate: 35%); middle value at least 2.5-fold (0.39 log units) away from the limit.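

In this assay, for the compounds shown here, hydrogen in place of dimethylamino gives an at least 8.4-fold higher number from compound 2 to compound 3 (0.92 log units; beyond the scatter), the first readable single-place step, and it ties the measurable growth inhibition of compound 2 to this group. Compound 3 gives > 150000 nM, a limit and not a number, so the step has no upper bound. The step from compound 1 to compound 3, hydrogen in place of fluoro, cannot be read, since both values are limits: the limit of > 150000 nM in this assay, at which 2 of the 3 values shown sit.

As far as these compounds go, whether a primary amine or a methoxy group at this place would keep the activity of dimethylamino remains open. Going by these compounds alone, with compound 2 the only one giving a number, no order among groups at this place can yet be set.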